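From carboxy to ethoxycarbonyl: compound 2 to compound 3

The source may hold more compounds than are shown below. What is called first, only, known or untested is meant among the compounds shown, and "the series" means these compounds.

Measured in a functional assay on Maver1 cells (Homo sapiens) for inhibition, read by luminescence and CellTiter-Glo, with a stated time of 72 h; a higher number here means a weaker inhibitor, a lower number a stronger inhibitor:
- compound 1 `C/C=C/C(=O)N1CCCC(n2nc(-c3ccc(Oc4ccccc4)cc3)cc2C(=O)OCC)C1`: 19600 nM
- compound 2 `C=CC(=O)N1CCCC(n2nc(-c3ccc(Oc4ccccc4)cc3)cc2C(=O)O)C1`: > 60000 nM (a limit)

Compound 2 has no numerical value in this assay and stands at the limit: the limit of > 60000 nM in this assay, at which 1 of the 2 values shown sits. Compound 3 `C=CC(=O)N1CCCC(n2nc(-c3ccc(Oc4ccccc4)cc3)cc2C(=O)OCC)C1` is still unmeasured. It differs from compound 2 by ethyl in place of hydrogen on an oxygen next to a carbonyl group, or carboxy to ethoxycarbonyl. For the measured compounds named here, no step between measured compounds is available as a guide. A step toward stronger inhibition, beyond the usual scatter, is expected in this assay because compound 1, which also carries ethoxycarbonyl, gives 19600 nM. The expected change is an at least 4.2-fold lower number from compound 2 to compound 3 (0.63 log units; beyond the scatter). For compound 3 the estimated value is 14000 nM, with an expected range of 4000 nM to 45000 nM.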

Compound 3, half-maximal inhibitory concentration: > 60000 nM
Compound 3: only a limit was reported (the forecaster's own chance of this, stated with the estimate: 12%); middle value at least 4.2-fold (0.63 log units) away from the limit.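

In this assay compound 3 gives > 60000 nM, which is a limit of the assay. Ethyl in place of hydrogen on the oxygen brings no measurable value, and the step between the carboxy and ethoxycarbonyl compounds cannot be read, since both stand at the same limit: the limit of > 60000 nM in this assay, at which 2 of the 3 values shown sit.

With ethoxycarbonyl held fixed, vinyl in place of prop-1-en-1-yl on a carbonyl carbon gives an at least 3.0-fold higher number from compound 1 to compound 3 (0.48 log units; beyond the scatter), so ethoxycarbonyl alone does not account for the measurable value of compound 1.

Going by these compounds, whether carboxy and ethoxycarbonyl differ at all remains open, and a pairing of carboxy with prop-1-en-1-yl would address this in the measurable range. Also open, on these data alone, is how a primary amide or a longer ester such as butoxycarbonyl would read with prop-1-en-1-yl on the carbonyl carbon.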